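The source may hold more compounds than are shown below. What is called first, only, known or untested is meant among the compounds shown, and "the series" means these compounds.

Of the compounds shown here, three have been tested in an ADME assay on BJ cells (Homo sapiens) for cytotoxicity, with a stated time of 72 h (a lower number here means that less compound is needed, a higher number that more compound is needed for the effect), and none of them gave a number. Compound 1 `C=C[C@@](C)(/C=C/c1ccc(OS(=O)(=O)c2ccc(C)cc2)cc1)CCC=C(C)C` gave only a limit, > 36600 nM. Compound 2 `C=C[C@@](C)(/C=C/c1ccc(O)c(/C=C/C#N)c1)CCC=C(C)C` also gave only a limit, > 36600 nM. Compound 3 `COc1ccc(/C=C/[C@@](C)(/C=C/c2ccc(O)c(/C=C/C#N)c2)CCC=C(C)C)cc1` likewise gave only a limit, > 23700 nM. Compound 3 therefore has no exact place among the three.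

Compound 4 `COc1ccc(/C=C/[C@@](C)(/C=C/c2ccc(O)cc2)CCC=C(C)C)cc1` differs from compound 3 by hydrogen in place of 2-cyanoethenyl on an aromatic carbon, ortho to a hydroxy group. For the measured compounds named here, the one measured step, a step that the two limits leave unreadable from compound 2 to compound 3, concerns a different part of the structure and offers no size to carry over. Some guidance comes from compound 1, which has no 2-cyanoethenyl and still stops at a limit, > 36600 nM. No step beyond the usual scatter is therefore expected in this assay, and compound 4 will most likely give only a limit too. The expected change is a step that the limit leaves unreadable from compound 3 to compound 4. For compound 4 the estimated value is 30000 nM, with an expected range from 10000 nM to 60000 nM.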

Compound 4, half-maximal effective concentration: > 36600 nM
Compound 4 ended at the assay's limit; the forecaster's own chance of this, stated with the estimate: 75%; at least 1.2-fold (0.08 log units) between middle value and limit.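

Compound 3 and compound 4 both gave only limits in this assay, and the step between them cannot be read. The compounds shown leave open at what concentration any of them would reach the half-maximal effect, and whether hydrogen in place of 2-cyanoethenyl changes that concentration at all.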